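Compound 3 to compound 4: the oxygen substituent

A few compounds are considered here, and "the series" means these few. Any claim that something is new, unique, unknown or untested is made for them only; others in the source may bear on it.

Measured in a functional assay on U-251 cells (Homo sapiens) for antiproliferative activity, read by MTT assay, with a stated time of 24 h; a lower number here means a stronger inhibitor, a higher number a weaker inhibitor:
compound 1 `COc1cc(OC)c(-c2coc3cc(OCC=C(C)C)ccc3c2=O)cc1OC`: 3500 nM
compound 2 `C=CCOc1ccc2c(=O)c(-c3cc(OC)c(OC)cc3OC)coc2c1`: 5900 nM
compound 3 `COc1cccc(C(=O)Oc2ccc3c(=O)c(-c4cc(OC)c(OC)cc4OC)coc3c2)c1`: > 10000 nM (a limit, not a number)

Compound 3 has no number in this assay and stands at the limit of > 10000 nM in this assay, at which 1 of the 3 values shown sits. Compound 4 `COc1cc(OC)c(-c2coc3cc(OCc4ccc(F)cc4)ccc3c2=O)cc1OC` differs from it in one group: 4-fluorobenzyl in place of (3-methoxyphenyl)carbonyl on an oxygen on an aromatic ring. The nearest guides are the two steps that put the same (3-methoxyphenyl)carbonyl on that oxygen. The first is an at least 2.8-fold higher number from compound 1 to compound 3 (0.45 log units; beyond the scatter). The second is an at least 1.6-fold higher number from compound 2 to compound 3 (0.22 log units; that floor lies within the scatter). Both give only floors, and neither starting compound carries 4-fluorobenzyl. The remaining step, a 1.7-fold higher number from compound 1 to compound 2 (0.23 log units; within the scatter), shows that these two groups give values within the scatter of each other. A step to a lower number is therefore expected, reversing those two steps, at least modest in size but uncertain, and compound 4 may also stay at the limit. The expected size is an at least 2.0-fold lower number from compound 3 to compound 4 (0.30 log units; that floor lies within the scatter). The value expected for compound 4 is 5000 nM, within an estimated range of 1800 nM to 12000 nM.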

Compound 4, half-maximal inhibitory concentration: 3200 nM
Compound 4: the middle estimate sits 1.6-fold (0.19 log units) above what was measured; the range from low to high includes it.
By their numbers in this assay, from the lowest: compounds 4, 1 and 2 (each within the scatter of the next). At a limit, above all of these: compound 3.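

In this assay, with 4-fluorobenzyl in place of (3-methoxyphenyl)carbonyl on the oxygen on an aromatic ring, the step is an at least 3.1-fold lower number from compound 3 to compound 4 (0.49 log units; beyond the scatter), so one six-membered aromatic ring in this substituent does not by itself go with a value at the limit. The benzyl ether compound 4 shows no separation from the allyl or 3-methylbut-2-en-1-yl compounds, with a 1.8-fold lower number from compound 2 to compound 4 (0.27 log units; within the scatter) and a 1.1-fold lower number from compound 1 to compound 4 (0.04 log units; within the scatter). The step from compound 3 is only a floor, since compound 3 has a limit and not a number: the limit of > 10000 nM in this assay, at which 1 of the 4 values shown sits.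

The compounds shown do not separate the carbonyl of compound 3 from its 3-methoxyphenyl part. As far as these compounds go, how this oxygen position responds to an amine, a carboxylic acid or a longer chain remains open.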